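One Methyl Less: What to Expect for Compound 4

The source may report more compounds than this note shows. Statements on the series, on what has been measured and on what is new or still open speak of the compounds shown alone.

Compound 1 `COc1ccc(CCC(=O)c2ccc(O)cc2)c(OC)c1` and compound 3 `COc1ccc(CCC(=O)c2ccc(O)cc2)c(O)c1` were both tested in a functional assay on HeLa cells (Homo sapiens) for cytotoxicity, read by MTT assay, with a stated time of 72 h; on this read-out higher numbers stand for weaker inhibition and lower numbers for stronger inhibition. In this assay compound 1 gives only a limit, > 100000 nM, not a measured number. Compound 3, in the same test, gives 46100 nM. The two structures differ in one place: hydrogen in place of methyl on an oxygen on an aromatic ring. The step this change produced is an at least 2.1-fold lower number from compound 1 to compound 3 (0.33 log units; beyond the scatter), and its true size is known only as a lower bound because of the limit of > 100000 nM in this assay, at which 2 of the 3 values shown sit.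

Compound 2 `COc1ccc(C(=O)CCc2c(OC)cc(O)cc2OC)cc1` carries a core that differs from the core of compound 1; that difference is not broken down here. In this assay compound 2 also gives only a limit, > 100000 nM. Compound 4 `COc1cc(O)cc(OC)c1CCC(=O)c1ccc(O)cc1` has not yet been measured. Going by the values given here, it differs from compound 2 by hydrogen in place of methyl on an oxygen on an aromatic ring, which is the same change as the one between compound 1 and compound 3, made around the same kind of surroundings.

Compound 4 is therefore expected to give roughly 60000 nM, because the same change gave an at least 2.1-fold lower number from compound 1 to compound 3 (0.33 log units; beyond the scatter) earlier in the series. For compound 4 this estimate means an expected step of an at least 1.6-fold lower number from compound 2 to compound 4 (0.22 log units; that floor lies within the scatter). The expected range for compound 4 runs from 25000 nM to 150000 nM, and since compound 2 itself reached only the limit of the test, a fair chance remains that compound 4 will again report a limit rather than a number.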

Compound 4, half-maximal inhibitory concentration: 49000 nM
Compound 4: middle estimate off by 1.2-fold (0.09 log units), on the high side; low and high end bracket the measured number.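

On the core of compound 2, the change from methoxy to hydroxy turns a limit into a measured number in this assay, giving an at least 2.0-fold lower number from compound 2 to compound 4 (0.30 log units; that floor lies within the scatter), so the step seen on the core of compound 1 has a counterpart here that points the same way. This is only two pairs of compounds, and it shows that the change can be carried from one core to another in direction, not that it carries over with the same size: the same change on two cores in this assay, an at least 2.1-fold lower number (0.33 log units; beyond the scatter) from compound 1 to compound 3 and an at least 2.0-fold lower number (0.30 log units; that floor lies within the scatter) from compound 2 to compound 4; the limit leaves it open whether they differ The true size of each step stays unknown, and neither pair says why the number falls, because each starting compound gives only a limit and not a measured value: the limit of > 100000 nM in this assay, at which 2 of the 4 values shown sit.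

The compounds shown carry only methoxy or hydroxy at the changed oxygen on the aromatic ring, so it remains open how an ethoxy group, an amine or a carboxylic acid would read in that place. It also remains open whether the same change at the other methoxy groups of these compounds would lower the number further, and whether it would do so to the same extent on both cores.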